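From a 4-methylphenyl to a phenethyl group on sulfur

The compounds below may be only part of what the source reports. "The series", "measured", "known", "first", "only" and "open" are said of these compounds alone.

Within the data shown here, in a functional assay on A549 cells (Homo sapiens) for inhibition, read by CCK-8 assay, with a stated time of 72 h, tested at 8 uM (a lower number here means less inhibition of growth, a higher number more inhibition of growth at the concentration tested), compound 1 `COc1ccc(SCc2ccc(/C=C/C(=O)Nc3ccccc3N)cc2)cc1OC` gives 80.6% while compound 2 `Cc1ccc(SCc2ccc(/C=C/C(=O)Nc3ccccc3N)cc2)cc1` gives 48.3% as the lower of the two numbers so far. Compound 3 `Nc1ccccc1NC(=O)/C=C/c1ccc(CSCCc2ccccc2)cc1` has phenethyl in place of 4-methylphenyl on a sulfur and the rest of compound 2 stays the same. Among the measured compounds shown here, the only measured step at that sulfur is large (a number 32.3 percentage points lower from compound 1 to compound 2 (beyond the scatter)) but gives no direction for a phenethyl group, so no step beyond the scatter is expected. The estimated step in this assay is small (a number 1.7 percentage points higher from compound 2 to compound 3 (within the scatter)). Compound 3 is expected at 50% with an estimated range from 27% to 74% for this measurement.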

Compound 3, percent growth inhibition at one concentration: 50.3%
The estimate for compound 3 lay 0.3 percentage points below the measured number; low and high end bracket the measured number.
By their numbers in this assay, from the lowest: compounds 2 and 3 (each within the scatter of the next); then compound 1.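

At this sulfur, this assay gives a number 2 percentage points higher from compound 2 to compound 3 (within the scatter), so moving from 4-methylphenyl to phenethyl leaves no difference that can be told from the scatter. The second step reads a number 30.3 percentage points lower from compound 1 to compound 3 (beyond the scatter), which shows that the large gap to 3,4-dimethoxyphenyl is not confined to 4-methylphenyl but also holds for phenethyl. Nothing at hand gives a reason for these numbers. Still open, as far as these compounds go, is what a single methoxy group would give on the phenyl ring, or an amine or a carboxylic acid there. From the compounds shown here alone, a benzyl group or a longer chain on this sulfur is equally open.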